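A few compounds are considered here, and "the series" means these few. Any claim that something is new, unique, unknown or untested is made for them only; others in the source may bear on it.

Measured in a functional assay on Malme-3M cells (Homo sapiens) for inhibition, read by sulforhodamine B assay, with a stated time of 48 h; a lower number here means a stronger inhibitor of growth, a higher number a weaker inhibitor of growth:
compound 1 `Nc1cc(N)c2nc(-c3ccccc3)c(NCc3ccc(Cl)c(Cl)c3)nc2c1`: 13800 nM
compound 2 `COc1ccc(CNc2nc3cc(N)cc(N)c3nc2-c2ccccc2)cc1OC`: 18600 nM

Compound 2 stands at the upper end of the two values shown, but it is separated from compound 1 only by a 1.3-fold higher number from compound 1 to compound 2 (0.13 log units; within the scatter), a step inside the scatter, so the two compounds cannot be told apart on this assay. Compound 3 `COc1ccc(CNc2nc3cc(N)cc(N)c3nc2-c2ccccc2)cc1` differs from compound 2 by hydrogen in place of methoxy on an aromatic carbon. Among the measured compounds shown here, no measured pair removes a methoxy group; the single measured step exchanges one disubstituted phenyl for another and was itself small, so it bears on the present change only loosely and gives no direction. The expectation for compound 3 in this assay is therefore no shift beyond the scatter, the expected step being a 1.1-fold lower number from compound 2 to compound 3 (0.04 log units; within the scatter). Compound 3 is estimated at 17000 nM, with a range from 7000 nM to 40000 nM.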

Compound 3, concentration for total growth inhibition: 22400 nM
Compound 3: middle estimate off by 1.3-fold (0.12 log units), on the low side; measured number inside the range.
By their numbers in this assay, from the lowest: compounds 1, 2 and 3 (each within the scatter of the next).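

Working from this assay, the exchange of 3,4-dimethoxyphenyl for 4-methoxyphenyl gives a 1.2-fold higher number from compound 2 to compound 3 (0.08 log units; within the scatter), so hydrogen in place of methoxy on the aromatic carbon ortho to a methoxy group and meta to a large group has no readable effect here. The wider exchange gives a 1.6-fold higher number from compound 1 to compound 3 (0.21 log units; within the scatter), so 3,4-dichlorophenyl, 3,4-dimethoxyphenyl and 4-methoxyphenyl on this chain carbon cannot be told apart in this assay. No supporting data bear on why this position tolerates the change.

Still open, from the compounds shown here alone, is whether any group on this aromatic carbon moves the number beyond the scatter, such as an amine, a carboxylic acid or a longer alkoxy chain. Also open, going by these compounds, is how the unsubstituted phenyl compares with these three compounds.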